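Adding one methyl group to the core of compound 2

A few compounds are considered here, and "the series" means these few. Any claim that something is new, unique, unknown or untested is made for them only; others in the source may bear on it.

In a functional assay on HUVEC cells (Homo sapiens) for inhibition, using NADPH, with a stated time of 2 h (on this read-out lower numbers stand for stronger inhibition and higher numbers for weaker inhibition), compound 2 `Cc1c(COc2cccc(OCC3CCOCC3)c2)[nH]c2ccccc2c1=O` gives 8.9 nM. Compound 1 `COC(C)(C)CCOc1cccc(OCc2[nH]c3ccccc3c(=O)c2C)c1` gives 8.3 nM, so these two cannot be told apart. Compound 3 `CC(C)c1c(COc2cccc(OCC3CCOCC3)c2)[nH]c2ccccc2c1=O` gives 54 nM, a clearly higher number than that of compound 2.

Compound 4 `Cc1ccc2[nH]c(COc3cccc(OCC4CCOCC4)c3)c(C)c(=O)c2c1` differs from compound 2 in one place: methyl in place of hydrogen on an aromatic carbon. In words, this is methyl in place of hydrogen on an aromatic carbon, on the six-membered aromatic ring of carbon only.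

Two measured steps offer some guidance. The step of a 1.1-fold higher number from compound 1 to compound 2 (0.03 log units; within the scatter) changes the group on the chain, at another part of the molecule, so it says little about this new position. The closer guide is the step of a 6.1-fold higher number from compound 2 to compound 3 (0.78 log units; beyond the scatter), which puts isopropyl in place of methyl on an aromatic carbon, though on a different carbon of the core. It shows that a change to an alkyl group on the core can matter. Among the compounds with values here, no measured compound carries a group on the ring that changes here, so the direction remains uncertain.

In this assay, a small rise is expected, similar to or smaller than the step to compound 3. The estimated change is a 1.3-fold higher number from compound 2 to compound 4 (0.13 log units; within the scatter). For compound 4, the expected value is 12 nM, within an estimated range of 4 nM to 35 nM.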

Compound 4, half-maximal inhibitory concentration: 38 nM
Beside the measured number, compound 4's estimate is 3.2-fold (0.50 log units) below it; the measured number lies above the stated range.
By their numbers in this assay, from the lowest: compounds 1 and 2 (each within the scatter of the next); then compounds 4 and 3 (each within the scatter of the next).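

In this assay, methyl in place of hydrogen on the six-membered aromatic ring of carbon only gives a 4.3-fold higher number from compound 2 to compound 4 (0.63 log units; beyond the scatter) and so moves the read-out toward weaker inhibition, which shows that this position is not indifferent to a single added carbon. Until now, the only sign that the core responds to a change came from a different carbon, where isopropyl in place of methyl gives a 6.1-fold higher number from compound 2 to compound 3 (0.78 log units; beyond the scatter) and the number also rises. The new result extends that sensitivity to the carbon-only ring, although no measurement shown here bears on why the number rises.

One methyl group on one carbon cannot tell whether the rise belongs to methyl alone or would follow any group placed there, and a single fluorine atom, a methoxy group or a nitrile on the same carbon would help to separate those cases. On these data alone, it also remains open whether the same methyl would have a similar effect alongside the 2-methoxy-2-methylpropyl group of compound 1, and whether the other carbons of this ring behave in the same way.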